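The source may report more compounds than this note shows. Statements on the series, on what has been measured and on what is new or still open speak of the compounds shown alone.

In a functional assay on Huh-7 cells (Homo sapiens) for cytotoxicity, read by CellTiter-Glo, with a stated time of 72 h (on this read-out lower numbers stand for stronger inhibition and higher numbers for weaker inhibition), compound 1 `C=C1C(=O)C2=C3[C@@H](CC[C@H]4C(=C)C(=O)O[C@@H]4[C@@H]13)CC[C@]21C(=O)C[C@H]2C(=C)CC[C@H]3C(=C)C(=O)O[C@@H]3[C@H]21` gives > 10000 nM, which is a limit and not a number. Compound 2 `C=C1C(=O)C2=C3[C@H]1[C@H]1OC(=O)C(=C)[C@@H]1CC[C@@]3(O)CC[C@]21C(=O)C[C@H]2C(=C)CC[C@H]3C(=C)C(=O)O[C@@H]3[C@H]21` gives > 10000 nM, which is also a limit. As far as these compounds go, the evidence therefore consists only of the limit of > 10000 nM in this assay, at which 2 of the 2 values shown sit, and the true potency of compound 2 remains unknown. Compound 3 `C=C1C(=O)C2=C3[C@H]1[C@H]1OC(=O)C(=C)[C@@H]1CC[C@]3(O)CC[C@]21C(=O)C[C@H]2C(=C)CC[C@H]3C(=C)C(=O)O[C@@H]3[C@H]21` differs from compound 2 as follows: the two compounds have the same atoms and bonds and differ only in configuration as drawn: 1 of 9 stereo elements differ; a stereocentre at a saturated ring carbon is drawn R in compound 2 and S in compound 3; a stereocentre at a saturated ring carbon is drawn R in compound 2 and S in compound 3. No change beyond the scatter is expected, and the estimated step is a step that the limit leaves unreadable from compound 2 to compound 3. The expected value for compound 3 is 12000 nM, within an estimated range of 4000 nM to 30000 nM.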

Compound 3, half-maximal inhibitory concentration: 2500 nM
Compound 3: the middle estimate sits 4.8-fold (0.68 log units) above what was measured; the measured number lies below the stated range.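

In this assay, a change of one saturated ring carbon from R to S, with no atom entering or leaving, gives an at least 4.0-fold lower number from compound 2 to compound 3 (0.60 log units; beyond the scatter). Hydroxy in place of hydrogen on a saturated ring carbon gives an at least 4.0-fold lower number from compound 1 to compound 3 (0.60 log units; beyond the scatter). Both steps start from a limit, so only their smallest possible size is known: the limit of > 10000 nM in this assay, at which 2 of the 3 values shown sit.

The compounds shown leave open whether the hydroxy itself matters at this position. A methoxy or an amine in its place, drawn in the same configuration as in compound 3, would test that.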